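A swapped five-membered ring on a shared core

The source may hold more compounds than are shown below. What is called first, only, known or untested is meant among the compounds shown, and "the series" means these compounds.

Measured so far in an assay on membranes from Chem-1 cells for displacement of a labelled ligand from prostaglandin E2 receptor EP3 subtype (Homo sapiens), read by scintillation counting, with a stated time of 2 h; on this read-out lower numbers stand for stronger inhibition and higher numbers for weaker inhibition:
- compound 1 `CC(C)C(/C=C1\NC(=O)NC1=O)c1ccc(-c2ccc3cccc(F)c3c2)[nH]c1=O` gives 43 nM
- compound 2 `CC(C)C(c1ccc(-c2ccc3cccc(F)c3c2)[nH]c1=O)C1NC(=O)NC1=O` gives 50 nM
- compound 3 `CCC(/C=C1\OC(=O)NC1=O)(CC)c1ccc(-c2ccc3cccc(C(C)C)c3c2)[nH]c1=O` gives 120 nM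

Compound 2 stands second highest of these three numbers. Its nearest neighbour is compound 1, and the step from compound 1 to compound 2 is a 1.2-fold higher number from compound 1 to compound 2 (0.07 log units; within the scatter), so the two cannot be told apart. Compound 3 is furthest, with a higher number than compound 2, but it differs from compound 2 in several places at once, so no single step can be read from that pair.

Compound 4 `C/C(=C1/OC(=O)NC1=O)C(c1ccc(-c2ccc3cccc(F)c3c2)[nH]c1=O)C(C)C` differs from compound 2 in one place: a group of 9 heavy atoms (5 carbon, 1 nitrogen, 3 oxygen; one five-membered non-aromatic ring with 2 hetero atoms) in place of a group of 7 heavy atoms (3 carbon, 2 nitrogen, 2 oxygen; one five-membered non-aromatic ring with 2 hetero atoms), on a saturated chain carbon bound to an aromatic carbon and a saturated chain carbon. Among the compounds with values here, the only measured single step, from compound 1 to compound 2, changed a ring on the same carbon and stayed within the scatter. The ring that enters in compound 4 also appears in compound 3, whose higher number is the only hint of a direction, though it is blurred by the other differences. For compound 4 the expected step is therefore a 1.5-fold higher number from compound 2 to compound 4 (0.18 log units; within the scatter) in this assay, a modest move toward a higher number. The estimate for compound 4 is 75 nM, with a range from 25 nM to 220 nM.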

Compound 4, inhibition constant: 17 nM
Estimate against measurement, compound 4: 4.4-fold (0.64 log units) above, outside the stated range (below it).
By their numbers in this assay, from the lowest: compound 4; then compounds 1 and 2 (each within the scatter of the next); then compound 3.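

In this assay, within the data shown here, the group on this saturated chain carbon can move the number beyond the scatter: the new ring gives a 2.9-fold lower number from compound 2 to compound 4 (0.47 log units; beyond the scatter) and a 2.5-fold lower number from compound 1 to compound 4 (0.40 log units; beyond the scatter), whereas the only earlier step at this carbon stayed within the scatter. Compared with the 2,5-dioxoimidazolidin-4-yl group, the entering group changes the heavy atoms, the double bonds and the hydrogen-bond donors and acceptors all at once, so this step cannot be pinned on any one of these features. Nothing measured here accounts for the shift.

On these data alone, whether an amine or a carboxylic acid on this carbon, in place of the ring, would keep such a low number remains open. Steps involving compound 3 cannot be read, since it differs from the others in several places, so it also remains open whether this ring would act the same way on another core.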